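The source may report more compounds than this note shows. Statements on the series, on what has been measured and on what is new or still open speak of the compounds shown alone.

Measured so far in a functional assay on MCF7 cells (Homo sapiens) for inhibition, read by CCK-8 assay, with a stated time of 48 h; a lower number here means a stronger inhibitor, a higher number a weaker inhibitor:

- compound 1, `COc1cc(-c2ccnc3cc(-c4ccc(F)cc4)nn23)cc(OC)c1OC`, gives 1280 nM.
- compound 2, `COc1cc(-c2ccnc3cc(-c4ccc(C)c(C)c4)nn23)cc(OC)c1OC`, gives 26 nM.
- compound 3, `COc1cc(-c2ccnc3cc(-c4cccc(C#N)c4)nn23)cc(OC)c1OC`, reaches only a limit of the assay, > 10000 nM.

Of the two compounds with a definite number, compound 1 has the higher one; its nearest neighbour is compound 2, reached by a 49-fold lower number from compound 1 to compound 2 (1.69 log units; beyond the scatter). The third value is a limit, (the limit of > 10000 nM in this assay, at which 1 of the 3 values shown sits), and the other measured step runs an at least 7.8-fold higher number from compound 1 to compound 3 (0.89 log units; beyond the scatter), so the substituent pattern on that aryl ring moves the read-out over a wide span in both directions.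

Compound 4, `CCOC(=O)c1ccc(-c2cc3nccc(-c4cc(OC)c(OC)c(OC)c4)n3n2)cc1`, is not yet measured. It differs from compound 1 by ethoxycarbonyl in place of fluoro on an aromatic carbon. The two measured steps that start from compound 1 bear on this change only loosely: neither places an ethoxycarbonyl at that position, and they pull opposite ways, the 3,4-dimethylphenyl giving a large gain and the 3-cyanophenyl a loss that is at least modest. Going by the values given here, with no closer precedent, the account expects no step beyond the scatter in this assay, though with a wide margin of doubt. For compound 4 the estimate is 1500 nM, with a range from 300 nM to 8000 nM. That estimate corresponds to a 1.2-fold higher number from compound 1 to compound 4 (0.07 log units; within the scatter).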

Compound 4, half-maximal inhibitory concentration: > 10000 nM
Compound 4 ended at the assay's limit; the forecaster's own chance of this, stated with the estimate: 20%; middle value at least 6.6-fold (0.82 log units) away from the limit.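

In this assay, ethoxycarbonyl in place of fluoro, on an aromatic carbon para to a large group, brings an at least 7.8-fold higher number from compound 1 to compound 4 (0.89 log units; beyond the scatter). Going by these compounds alone, until now, the only loss from compound 1 came with the 3-cyanophenyl of compound 3; this result adds a second loss, this time from a change at the very place the fluoro occupies, where five heavy atoms enter for one and two hydrogen-bond acceptors come in. The value of compound 4 is a limit of the assay and not a number, so the full size of this step stays unknown, and no order can be read between compound 4 and compound 3, which share that limit: the limit of > 10000 nM in this assay, at which 2 of the 4 values shown sit.

The compounds shown leave open whether the loss belongs to the ethoxycarbonyl as a whole or to one part of it, which a carboxylic acid, a methyl ester or a primary amide in the same place would help to separate. They also leave open whether a single methyl or a methoxy there would keep any of the gain seen with the 3,4-dimethylphenyl of compound 2.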